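The source may report more compounds than this note shows. Statements on the series, on what has been measured and on what is new or still open speak of the compounds shown alone.

Measured compounds and their values in a physicochemical assay for lipophilicity, using the shake flask method, in phosphate buffer, measured as octanol-water partition, with a stated time of 24 h, at pH 7.4; on this read-out lower numbers stand for lower lipophilicity and higher numbers for higher lipophilicity:
compound 1 `COc1ccc(-c2nn(-c3ccccc3F)c3c2CCS(=O)(=O)O3)cc1`, giving 2.62
compound 2 `O=S1(=O)CC(c2ccc(F)cc2)c2c(C3CC3)nn(-c3ccccc3F)c2O1`, giving 1.76
compound 3 `O=S1(=O)CC(c2ccc(F)cc2)c2c(C3CC3)nn(-c3ccccc3Cl)c2O1`, giving 2.04

Compound 2 and compound 3 share a core and differ in a single place: chloro in place of fluoro on an aromatic carbon. In this assay this change made a step of a number 0.28 log units higher from compound 2 to compound 3 (within the scatter). Compound 1 stands highest of the three measured compounds; compound 3 is the nearest to it, lying lower by a margin beyond the scatter, and compound 2 is the furthest, also lower by a margin beyond the scatter. The difference between the core of compound 1 and the core of compound 2 is not broken down here.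

Compound 4 `COc1ccc(-c2nn(-c3ccccc3Cl)c3c2CCS(=O)(=O)O3)cc1` has not yet been measured in this assay. It relates to compound 1 exactly as compound 3 relates to compound 2: chloro in place of fluoro on an aromatic carbon. The surroundings of the place are described in the same words for both pairs, so this is the same change carried onto a different core. Going by the values given here, only one measured instance of it is available, and the expectation rests on that single step. Compound 4 is expected to lie at the end of a step of a number 0.28 log units higher from compound 1 to compound 4 (within the scatter) from its parent, because the same change earlier produced a number 0.28 log units higher from compound 2 to compound 3 (within the scatter). Compound 4 is therefore estimated at 2.9, with a range from 2.55 to 3.25.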

Compound 4, partition coefficient: 3.04
Estimate against measurement, compound 4: 0.14 log units below; measured number inside the range.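

Carried onto a second core, chloro in place of fluoro on an aromatic carbon gave a number 0.42 log units higher from compound 1 to compound 4 (beyond the scatter) in this assay, and this step points the same way as the earlier a number 0.28 log units higher from compound 2 to compound 3 (within the scatter), so the direction of the change held on both cores shown. This does not show that the step has a fixed size or that the direction would hold on a further core: the comparison rests on just two matched pairs, only the newer step is printed as beyond the scatter, and the two cores themselves differ in more than one place. No supporting measurement is available to explain the result on either core.

The compounds shown carry only fluoro or chloro at this place on the aromatic ring, so it remains open what a bromo, a methyl, a methoxy or an amine in the same place would give in this assay on either core. Also open, on these data alone, is whether a carboxylic acid or a longer chain at that place would follow the same direction, and how the separate differences between the two cores contribute to the read-out.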